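A Methylsulfanyl for Aminoamino Swap Carried to a Second Core

This account rests on a few compounds, and the source may have more. Where it says the series, first, only, none or still open, it means among the compounds named here.

Compound 1 `COc1ccc(-c2nc(SC)n(C)c(=O)c2C#N)cc1` and compound 2 `COc1ccc(-c2nc(NN)n(C)c(=O)c2C#N)cc1` are built on one core, while compound 3 `Cn1c(NN)nc(-c2cccc(O)c2O)c(C#N)c1=O` carries another. In a functional assay, with a stated time of 150 min (on this read-out higher numbers stand for weaker inhibition and lower numbers for stronger inhibition), compound 1 gives 73 ug/mL. In this assay compound 2 gives 56 ug/mL, and compound 3 gives 44 ug/mL. Between compound 2 and compound 1 the change is methylsulfanyl in place of aminoamino on an aromatic carbon, and it made a 1.3-fold higher number from compound 2 to compound 1 (0.12 log units; within the scatter). How the core of compound 3 differs from that of compound 2 is not broken down here; what the two values show is that they lie close together.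

Compound 4 `CSc1nc(-c2cccc(O)c2O)c(C#N)c(=O)n1C` has not yet been measured in this assay. It arises from compound 3 by the same kind of change, (methylsulfanyl in place of aminoamino on an aromatic carbon), whose surroundings are described in the same words as before. Because of a 1.3-fold higher number from compound 2 to compound 1 (0.12 log units; within the scatter), the estimate for compound 4 means a 1.3-fold higher number from compound 3 to compound 4 (0.11 log units; within the scatter). In this assay compound 4 is therefore expected to give about 57 ug/mL, with the likely range running from 30 ug/mL to 110 ug/mL.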

Compound 4, half-maximal inhibitory concentration: 53 ug/mL
Estimate against measurement, compound 4: 1.1-fold (0.03 log units) above; the measured number falls inside the stated range.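

In this assay, methylsulfanyl in place of aminoamino on the second core gives a 1.2-fold higher number from compound 3 to compound 4 (0.08 log units; within the scatter), and set beside the step on the first core, the two agree: the same change on two cores in this assay, a 1.3-fold higher number (0.12 log units; within the scatter) from compound 2 to compound 1 and a 1.2-fold higher number (0.08 log units; within the scatter) from compound 3 to compound 4, 1.1-fold (0.03 log units) apart, within the scatter of two such steps The change therefore carried over from the core of compound 2 to the core of compound 3 without any difference that can be told apart. This does not show that the swap itself moves the number on either core, since both steps lie within the scatter, and two cores cannot establish a rule for the whole series.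

The compounds shown carry only aminoamino or methylsulfanyl at the aromatic carbon between two ring nitrogen atoms, so it remains open how a longer chain on the sulfur or a cyclic amine would read in this assay. As far as these compounds go, it also remains open whether the same small step would hold on a core with a carboxylic acid in place of the cyano group.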